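The compounds below may be only part of what the source reports. "The series", "measured", "known", "first", "only" and "open" are said of these compounds alone.

Measured so far:
compound 1, `O=C(NC1(C(=O)NO)CCC1)c1ccc(C#Cc2ccccc2)cc1`: a physicochemical assay for lipophilicity; a higher number here means a more lipophilic compound, a lower number a more polar compound > 3
compound 2, `O=C(NC1(C(=O)NO)CCCCC1)c1ccc(C#Cc2ccccc2)cc1`: this assay > 3

Compound 1 stands at a limit of the assay, not at a number: in this assay compound 1 reads > 3. Compound 2 likewise reaches only a limit in this assay, > 3. Among the measured compounds shown here, both measured values sit at that limit (the limit of > 3 in this assay, at which 2 of the 2 values shown sit), so no step between measured compounds can be sized.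

Compound 3, `CC(NC(=O)c1ccc(C#Cc2ccccc2)cc1)C(=O)NO`, is not yet measured in this assay. Against compound 1 it shows (1-(hydroxycarbamoyl)ethyl in place of 1-(hydroxycarbamoyl)cyclobutyl on an amide-type nitrogen), the entering group having no ring and fewer heavy atoms. The step from compound 1 to compound 3 in this assay is expected to be downward and beyond the usual scatter, roughly a number at least 0.50 log units lower from compound 1 to compound 3 (beyond the scatter). Compound 3 is therefore estimated at 2.5, between 1.9 and 3.1.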

Compound 3, distribution coefficient: > 3
Compound 3 was reported as a limit (the forecaster's own chance of this, stated with the estimate: 25%); middle value at least 0.50 log units from the limit.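

Compound 1 and compound 3 give no readable step in this assay, because each reaches only a limit of the assay: the limit of > 3 in this assay, at which 3 of the 3 values shown sit.

On these data alone, whether 1-(hydroxycarbamoyl)ethyl in place of 1-(hydroxycarbamoyl)cyclobutyl on the amide-type nitrogen shifts this assay at all, and by how much, stays open.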